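The compounds below may be only part of what the source reports. "The series", "measured", "known", "first", "only" and "open" are said of these compounds alone.

Three compounds were tested in a functional assay on HCT-116 cells (Homo sapiens) for antiproliferative activity, read by CCK-8 assay, with a stated time of 72 h, tested at 2 uM; on this read-out higher numbers stand for a stronger effect at the one concentration tested and lower numbers for a weaker effect. Compound 1, `CC(C)n1cnc2c(Nc3cccc(Cl)c3)nc(NCOCc3ccc(C(=O)Nc4ccccc4N)cc3)nc21`, gives 7.12% in this assay. Compound 2, `Nc1ccccc1NC(=O)/C=C/c1ccc(Cn2cnc3c(Nc4cccc(Cl)c4)nc(Cl)nc32)cc1`, gives 12.9%, and compound 3, `Nc1ccccc1NC(=O)c1ccc(Cn2cnc3c(Nc4ccccc4)nc(Cl)nc32)cc1`, gives 71.4%. Among these three numbers compound 2 holds the second highest place: its nearest neighbour is compound 1, whose number lies within the usual scatter of the measurement, so the two cannot be told apart, while compound 3 stands well beyond the scatter on the higher side.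

The compound not yet measured is compound 4, `Cc1ccc(Nc2nc(Cl)nc3c2ncn3Cc2ccc(/C=C/C(=O)Nc3ccccc3N)cc2)cc1`. It differs from compound 2 in one place only: 4-methylphenyl in place of 3-chlorophenyl on a nitrogen on an aromatic ring. Among the measured compounds shown here, no pair of measured compounds differs in just this way, so the effect of this exchange has not been observed directly, and the gap between compound 2 and compound 3 involves more than one change.

With nothing in the data pointing to a large effect, a step of a number 5.1 percentage points higher from compound 2 to compound 4 (within the scatter) is expected, which would not clear the scatter. Compound 4 is therefore estimated at 18%, with a plausible range from 5% to 45%.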

Compound 4, a percentage reported as inhibition, at one concentration (the size of the read-out at that concentration, not a potency): 0.27%
Compound 4: middle estimate off by 17.7 percentage points, on the high side; measured number outside the range, below it.
By their numbers in this assay, from the lowest: compounds 4, 1 and 2 (each within the scatter of the next, the first and the last beyond it); then compound 3.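

Among the compounds shown here, this is the first direct reading of a change at this place, on a nitrogen on an aromatic ring: in this assay, 4-methylphenyl in place of 3-chlorophenyl gives a number 12.6 percentage points lower from compound 2 to compound 4 (beyond the scatter) and so clears the scatter. The number therefore responds to the exchange even though both groups have 7 heavy atoms and one six-membered aromatic ring of carbon only. No measurement at hand explains why the number falls.

The exchange swaps the substituent and moves it at once, so the compounds shown cannot separate the two changes, whereas 3-methylphenyl or 4-chlorophenyl on the same nitrogen could. From the compounds shown here alone, compound 3 carries phenyl here but differs from compound 2 in more than one place, and how a ring bearing an amine or a carboxylic acid would behave also stays open.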